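This account rests on a few compounds, and the source may have more. Where it says the series, first, only, none or still open, it means among the compounds named here.

Measured compounds in a physicochemical assay for solubility, in phosphate buffer, with a stated time of 24 h, at pH 7.4, tested at 100 uM; a lower number here means a less soluble compound, a higher number a more soluble compound:
compound 1, `O=C(NCc1ccc(S(=O)(=O)c2ccccc2)cc1)NCc1cccnc1`, gives 10000 nM
compound 2, `O=C(NCc1ccc(S(=O)(=O)c2ccccc2)cc1)N1Cc2cccnc2C1`, gives 144000 nM
compound 3, `O=C(NCc1ccc(S(=O)(=O)C2CCOCC2)cc1)N1Cc2ccncc2C1`, gives 206000 nM

Compound 3 stands at the highest of the three numbers. Compound 2 lies within the scatter of it, so the two cannot be set in order; compound 1 sits well beyond the scatter, lower than both. The only step measured among these compounds is a 14-fold higher number from compound 1 to compound 2 (1.16 log units; beyond the scatter), a change on the carbonyl carbon.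

Compound 4, `O=C(NCc1ccc(S(=O)(=O)N2CC3(CCOCC3)C2)cc1)N1Cc2ccncc2C1`, differs from compound 3 at a different place: a group of 9 heavy atoms (7 carbon, 1 nitrogen, 1 oxygen; one four-membered non-aromatic ring with 1 hetero atom, one six-membered non-aromatic ring with 1 hetero atom) in place of a group of 6 heavy atoms (5 carbon, 1 oxygen; one six-membered non-aromatic ring with 1 hetero atom), on a sulfonyl sulfur. Going by the values given here, none of the measured steps touches the sulfonyl sulfur, so nothing among the three compounds bears directly on this change. The large step from compound 1 to compound 2 shows that this series can move a long way in this assay, but it was made at the carbonyl carbon and says nothing about the group on the sulfonyl sulfur. Lacking any such step, the expectation for compound 4 is a change no larger than the scatter, a 1.1-fold lower number from compound 3 to compound 4 (0.06 log units; within the scatter), in either direction. Compound 4 is therefore estimated to give 180000 nM, with a range from 90000 nM to 360000 nM.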

Compound 4, solubility: 272000 nM
The estimate for compound 4 lay 1.5-fold (0.18 log units) below the measured number; the range from low to high includes it.
By their numbers in this assay, from the lowest: compound 1; then compounds 2, 3 and 4 (each within the scatter of the next).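

In this assay, the first step measured at the sulfonyl sulfur, where the group of 9 heavy atoms with its four-membered and six-membered non-aromatic rings takes the place of oxan-4-yl, is a 1.3-fold higher number from compound 3 to compound 4 (0.12 log units; within the scatter), so compound 3 and compound 4 cannot be set in order. Going by these compounds alone, this exchange of a single ring for a two-ring group on the sulfonyl sulfur therefore leaves no effect that can be told from the scatter, whereas the one earlier step, made on the carbonyl carbon, is a 14-fold higher number from compound 1 to compound 2 (1.16 log units; beyond the scatter) and lies beyond it. No measurement is available that would explain this result.

The compounds shown leave open whether the sulfonyl sulfur stays this undemanding in this assay when it carries a quite different group, such as an open-chain dialkylamine or a ring bearing a carboxylic acid. They also leave open whether the same exchange would give a similar step on the core of compound 2, since compound 2 and compound 3 differ in more than one place.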